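This account rests on a few compounds, and the source may have more. Where it says the series, first, only, none or still open, it means among the compounds named here.

Measured compounds:
- compound 1 `Cc1ccc(C2(CNC(=O)Nc3c(C(C)C)cccc3C(C)C)CCCC2)cc1` – 25 nM
- compound 2 `COc1ccc(C2(CNC(=O)Nc3c(C(C)C)cccc3C(C)C)CCCC2)cc1` – 31 nM

In an assay on microsomes for inhibition of acyl-CoA:cholesterol acyltransferase (Oryctolagus cuniculus) (a higher number here means a weaker inhibitor, a lower number a stronger inhibitor), compound 2 holds the higher of the two numbers, with compound 1 the nearest, a gap described as within the scatter. Compound 3 `CC(C)c1cccc(C(C)C)c1NC(=O)NCC1(c2cccc(N)c2)CCCC1` differs from compound 2 by 3-aminophenyl in place of 4-methoxyphenyl on a saturated ring carbon. Among the measured compounds shown here, the only measured step, a 1.2-fold higher number from compound 1 to compound 2 (0.09 log units; within the scatter), touched the same aromatic ring but swapped only a small group, so it says little about trading the whole 4-methoxyphenyl for 3-aminophenyl. For the measured compounds named here, with no closer precedent, compound 3 is expected to stay in a similar range, with a wide margin either way, giving an estimated step of a 1.6-fold higher number from compound 2 to compound 3 (0.21 log units; within the scatter) and an estimate for compound 3 of 50 nM, between 12 nM and 200 nM.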

Compound 3, half-maximal inhibitory concentration: 21 nM
Beside the measured number, compound 3's estimate is 2.4-fold (0.38 log units) above it, within the range that was stated.
By their numbers in this assay, from the lowest: compounds 3, 1 and 2 (each within the scatter of the next).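

In this assay, putting 3-aminophenyl on the saturated ring carbon gives a 1.5-fold lower number from compound 2 to compound 3 (0.17 log units; within the scatter) and a 1.2-fold lower number from compound 1 to compound 3 (0.08 log units; within the scatter). Unlike the earlier step, which swapped only a small group, these steps change both the group on the aromatic ring and where it sits, yet neither moves the number beyond the scatter. No measurement here explains this tolerance. The compounds shown leave open whether the amine or its place on the ring matters, which 4-aminophenyl and 3-methoxyphenyl would separate. As far as these compounds go, how a carboxylic acid on that ring would read also remains open.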